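A few compounds are considered here, and "the series" means these few. Any claim that something is new, unique, unknown or untested is made for them only; others in the source may bear on it.

Measured in a functional assay on HL-60 cells (Homo sapiens) for cytotoxicity, read by luminescence and CellTiter-Glo, with a stated time of 3 days; a lower number here means a stronger inhibitor, a higher number a weaker inhibitor:
- compound 1 `N#Cc1ccc(NC(=O)c2ccc(-c3cccnc3)cc2O)cc1`: 6660 nM
- compound 2 `N#Cc1ccc(NC(=O)c2ccc(C(F)(F)F)cc2O)cc1`: 1030 nM
- compound 3 `COc1ccc(C(=O)Nc2ccc(C#N)cc2)c(O)c1`: 5470 nM

Compound 3 (5470 nM) cannot be separated from compound 1, given a 1.2-fold lower number from compound 1 to compound 3 (0.09 log units; within the scatter). Compound 2 stands apart from both, with a 6.5-fold lower number from compound 1 to compound 2 (0.81 log units; beyond the scatter) and a 5.3-fold higher number from compound 2 to compound 3 (0.73 log units; beyond the scatter).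

The next step leads to compound 4 `N#Cc1ccc(NC(=O)c2ccc(-c3ccccc3)cc2O)cc1`, which has phenyl in place of methoxy on an aromatic carbon, meta to a hydroxy group and para to a large group (phenyl in place of methoxy on an aromatic carbon). Among the compounds with values here, no measurement yet pairs phenyl with any other group, so the reading is indirect. The nearest measured structure is compound 1, which has pyridin-3-yl where compound 4 has phenyl. Swapping that group for methoxy gave a 1.2-fold lower number from compound 1 to compound 3 (0.09 log units; within the scatter), so a change between methoxy and an aromatic ring has so far not moved the number in this assay. Within the data shown here, the only steps beyond the scatter, a 6.5-fold lower number from compound 1 to compound 2 (0.81 log units; beyond the scatter) and a 5.3-fold higher number from compound 2 to compound 3 (0.73 log units; beyond the scatter), both involve trifluoromethyl, which plays no part in this change. They serve only to widen the range on the lower side.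

No step beyond the scatter is therefore expected, with at most a slight lean towards a lower number. The expected outcome is a 1.6-fold lower number from compound 3 to compound 4 (0.19 log units; within the scatter). For compound 4 the estimated value is 3500 nM, with an expected range from 1200 nM to 10000 nM.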

Compound 4, half-maximal inhibitory concentration: 700 nM
The estimate for compound 4 lay 5.0-fold (0.70 log units) above the measured number, outside the stated range (below it).
By their numbers in this assay, from the lowest: compounds 4 and 2 (each within the scatter of the next); then compounds 3 and 1 (each within the scatter of the next).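

Within the data shown here, with a 9.5-fold lower number from compound 1 to compound 4 (0.98 log units; beyond the scatter) in this assay, the position on the aromatic carbon, meta to a hydroxy group and para to a large group, distinguishes between two six-membered aromatic rings, so an aromatic ring as such does not set the number; the earlier compounds could not show this, as pyridin-3-yl and methoxy stood within the scatter of each other. With a 7.8-fold lower number from compound 3 to compound 4 (0.89 log units; beyond the scatter) phenyl separates from methoxy as well, whereas with a 1.5-fold lower number from compound 2 to compound 4 (0.17 log units; within the scatter) phenyl and trifluoromethyl cannot be told apart, which places compounds 2 and 4 together in a lower tier and compounds 1 and 3 in a higher one, even though phenyl and trifluoromethyl share little in structure and compound 1 carries a ring much like that of compound 4. No supporting measurement is available to explain why these groups fall into these two tiers.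

Open, going by these compounds, is whether the gap between phenyl and pyridin-3-yl depends on where the ring nitrogen sits, as pyridin-2-yl or pyridin-4-yl would test. Also open, on these data alone, is how this position responds to a saturated ring such as cyclohexyl, or to a phenyl ring carrying an amine or a carboxylic acid.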